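This account rests on a few compounds, and the source may have more. Where it says the series, first, only, none or still open, it means among the compounds named here.

In an ADME assay on isolated protein for inhibition of carbonic anhydrase 4 (Homo sapiens), read by stopped-flow, with a stated time of 15 min (on this read-out higher numbers stand for weaker inhibition and lower numbers for stronger inhibition), compound 1 `CN(C)c1ccccc1S(=O)(=O)[N-][N+](=O)[O-]` gives 32200 nM, and compound 2 `Nc1ccccc1S(=O)(=O)[N-][N+](=O)[O-]` gives 39200 nM. The change between them is amino in place of dimethylamino on an aromatic carbon, and it made a step of a 1.2-fold higher number from compound 1 to compound 2 (0.09 log units; within the scatter). Compound 3 `CN(C)c1ccc(S(=O)(=O)[N-][N+](=O)[O-])cc1` gives 11000 nM in this assay, the lowest of the three numbers, with compound 1 and compound 2 both beyond the scatter above it; how the core of compound 3 differs from the core of compound 1 is not broken down here. Compound 4 `Nc1ccc(S(=O)(=O)[N-][N+](=O)[O-])cc1` has not yet been measured in this assay. It differs from compound 3 by amino in place of dimethylamino on an aromatic carbon, which is the same kind of change as that from compound 1 to compound 2, but the place differs: there the amino sits ortho to a group of 7 heavy atoms, here para to a group of 7 heavy atoms. Since the earlier step of a 1.2-fold higher number from compound 1 to compound 2 (0.09 log units; within the scatter) stayed within the scatter, compound 4 is expected to move by about a 1.2-fold higher number from compound 3 to compound 4 (0.07 log units; within the scatter) from compound 3. Compound 4 is therefore estimated at 13000 nM in this assay, most likely between 6000 nM and 30000 nM.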

Compound 4, inhibition constant: 23600 nM
Compound 4: the middle estimate sits 1.8-fold (0.26 log units) below what was measured, within the range that was stated.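

In this assay, amino in place of dimethylamino on an aromatic carbon gives a 2.1-fold higher number from compound 3 to compound 4 (0.33 log units; beyond the scatter), a modest step. Set beside the earlier step on the other core, it cannot be told apart from it: the same change on two cores in this assay, a 1.2-fold higher number (0.09 log units; within the scatter) from compound 1 to compound 2 and a 2.1-fold higher number (0.33 log units; beyond the scatter) from compound 3 to compound 4, 1.8-fold (0.25 log units) apart, within the scatter of two such steps These two pairs therefore give no ground for treating the change as different on the two cores, but they do not show that it has one fixed size, since only one of the two steps lies beyond the scatter, and two pairs cannot establish a rule for the series or explain the result.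

The compounds shown leave open what an intermediate group such as methylamino, or a larger one such as diethylamino, would give on either core in this assay. They also leave open whether a carboxylic acid on the same aromatic carbon would give numbers near those of the amino and dimethylamino compounds.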